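Swapping the Hydroxamate Linker at the Triazole

The source may report more compounds than this note shows. Statements on the series, on what has been measured and on what is new or still open speak of the compounds shown alone.

Compound 1 `O=C(/C=C/c1cn([C@@H]2C[C@H](CO)N(CCCc3ccccc3)C2)nn1)NO` gives 12% in an assay on Sf9 cells for inhibition of histone deacetylase 11 (Homo sapiens), read by fluorescence, tested at 0.5 uM; a higher number here means more inhibition at the concentration tested (going by the name of the read-out), a lower number less inhibition. Compound 2 `O=C(NO)c1ccc(-c2cn([C@H]3C[C@@H](CO)N(CCCc4ccccc4)C3)nn2)cc1` stands only at a limit of this assay, reported as < 10%, which is the limit of < 10% in this assay, at which 1 of the 2 values shown sits. Compound 3 `O=C(/C=C/c1cn([C@H]2C[C@@H](CO)N(CCCc3ccccc3)C2)nn1)NO` carries 2-(hydroxycarbamoyl)ethenyl in place of 4-(hydroxycarbamoyl)phenyl on an aromatic carbon. Compound 3 differs only in the handedness of its two stereocentres from compound 1, which already bears this same group and gives 12% in this assay. The step expected here is a number at least 2 percentage points higher from compound 2 to compound 3 (that floor lies within the scatter), no larger than the scatter and perhaps none at all. Compound 3 is therefore estimated at 12%, with a range from 4% to 25%.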

Compound 3, a percentage reported as inhibition, at one concentration (the size of the read-out at that concentration, not a potency): 31%
Compound 3: the middle estimate sits 19 percentage points below what was measured; the whole stated range lies below it.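

In this assay, 2-(hydroxycarbamoyl)ethenyl in place of 4-(hydroxycarbamoyl)phenyl on the aromatic carbon gives a number at least 21 percentage points higher from compound 2 to compound 3 (beyond the scatter). Compound 2 stands at a limit of the assay, not at a number: the limit of < 10% in this assay, at which 1 of the 3 values shown sits. With the same group in place, the configuration of the shared core also matters, with a number 19 percentage points higher from compound 1 to compound 3 (beyond the scatter), and this step can be assigned to the drawn stereocentres alone: the fact that compounds 1 and 3 differ only in the configuration as drawn

As far as these compounds go, it remains open whether a carboxylic acid or a longer chain at this position would keep the inhibition. From the compounds shown here alone, it also remains open whether 4-(hydroxycarbamoyl)phenyl responds to configuration in the same way.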